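This account rests on a few compounds, and the source may have more. Where it says the series, first, only, none or still open, it means among the compounds named here.

In a functional assay on HUVEC cells (Homo sapiens) for antiproliferative activity, read by MTT assay, with a stated time of 24 h (on this read-out lower numbers stand for stronger inhibition and higher numbers for weaker inhibition), three compounds on a shared core have been measured. Compound 1 `COc1cc(OC)c(-c2coc3cc(OCC(=O)c4cccc(C(F)(F)F)c4)ccc3c2=O)cc1OC` gives > 10000 nM, which is a limit and not a number. Compound 2 `COc1cc(OC)c(-c2coc3cc(OCc4ccccc4F)ccc3c2=O)cc1OC` gives a real number, 4300 nM. Compound 3 `COc1cc(OC)c(-c2coc3cc(OCc4ccccc4C#N)ccc3c2=O)cc1OC` gives > 10000 nM, again a limit, and so stands at the limit of > 10000 nM in this assay, at which 2 of the 3 values shown sit.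

Compound 4 `COc1cc(OC)c(-c2coc3cc(OCc4ccccc4Br)ccc3c2=O)cc1OC` changes compound 3 by one group: bromo in place of cyano on an aromatic carbon, ortho to a large group (bromo in place of cyano on an aromatic carbon). The closest measured change is an at least 2.3-fold higher number from compound 2 to compound 3 (0.36 log units; beyond the scatter), where cyano replaced fluoro on that same carbon. The step of an at least 2.3-fold lower number from compound 1 to compound 2 (0.36 log units; beyond the scatter) also shows that compound 2 is the only one to leave the limit. Like compound 2, which reads 4300 nM, compound 4 has no cyano, so it is expected to return towards a measurable number. The expected step is an at least 1.8-fold lower number from compound 3 to compound 4 (0.25 log units; that floor lies within the scatter), a modest one towards stronger inhibition. For compound 4 the estimated value is 5500 nM, with an expected range from 2200 nM to 10000 nM.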

Compound 4, half-maximal inhibitory concentration: > 10000 nM
Compound 4: only a limit was reported (the forecaster's own chance of this, stated with the estimate: 35%); at least 1.8-fold (0.25 log units) between middle value and limit.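

In this assay, bromo in place of fluoro on this aromatic carbon gives an at least 2.3-fold higher number from compound 2 to compound 4 (0.36 log units; beyond the scatter), so the loss seen with cyano is not confined to that group. Compound 4 gives > 10000 nM, which is a limit and not a number, and the steps from compound 3 and from compound 1 to compound 4 cannot be read. Among the groups shown on this carbon, fluoro in compound 2 remains the only one to give a measured number, and the other compounds share a single limit: the limit of > 10000 nM in this assay, at which 3 of the 4 values shown sit.

The limits leave the order of cyano and bromo on this carbon unknown. From the compounds shown here alone, whether chloro, methyl, methoxy or an amine on the same carbon would give a measurable number also stays open.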